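Nitro in place of amino, compound 2 to compound 3

The compounds below may be only part of what the source reports. "The series", "measured", "known", "first", "only" and "open" are said of these compounds alone.

Among the compounds with values here, in a functional assay on MCF7 cells (Homo sapiens) for antiproliferative activity, read by MTT assay, with a stated time of 72 h (a lower number here means a stronger inhibitor, a higher number a weaker inhibitor), compound 2 (`COc1cc(-n2cnc3ccc(-c4cccc(N)c4)cc32)cc(OC)c1OC`) gives 180 nM and holds the lowest of the two numbers so far, while compound 1 (`COc1cc(-n2cnc3ccc(-c4ccc([N+](=O)[O-])cc4)cc32)cc(OC)c1OC`) gives 740 nM as its nearest neighbour. Compound 3 (`COc1cc(-n2cnc3ccc(-c4cccc([N+](=O)[O-])c4)cc32)cc(OC)c1OC`) has nitro in place of amino on an aromatic carbon. Within the data shown here, the only measured step (a 4.1-fold lower number from compound 1 to compound 2 (0.61 log units; beyond the scatter)) lies beyond the scatter, but it changes group and place together, so it bears only in part. Compound 1 also carries nitro at 740 nM and so a smaller step toward a higher number is expected. The estimated step (a 2.8-fold higher number from compound 2 to compound 3 (0.44 log units; beyond the scatter)) reflects this. Compound 3 is estimated at 500 nM with 170 nM to 1400 nM as the expected range.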

Compound 3, half-maximal inhibitory concentration: 4560 nM
For compound 3 the middle estimate is 9.1-fold (0.96 log units) below the measured one, outside the stated range (above it).
By their numbers in this assay, from the lowest: compound 2; then compound 1; then compound 3.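

In this assay, nitro in place of amino on this aromatic carbon, meta to a large group, gives a 25-fold higher number from compound 2 to compound 3 (1.40 log units; beyond the scatter) as a large step with the place held fixed. With nitro held fixed, 3-nitrophenyl in place of 4-nitrophenyl gives a 6.2-fold higher number from compound 1 to compound 3 (0.79 log units; beyond the scatter) as a step of place alone, so group and place, changed together in the earlier step, now each count separately. No measurement at hand accounts for either step.

Still open, going by these compounds, is whether amino depends on place as nitro does. Also open, on these data alone, is how a hydroxyl or a carboxylic acid on this carbon would compare with amino and nitro.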